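A few compounds are considered here, and "the series" means these few. Any claim that something is new, unique, unknown or untested is made for them only; others in the source may bear on it.

In an assay on RBL-1 cells for inhibition of Polyunsaturated fatty acid 5-lipoxygenase (Rattus norvegicus) (on this read-out higher numbers stand for weaker inhibition and lower numbers for stronger inhibition), the measured compounds stand as follows: compound 1 `COc1cc(/C=C/C=C/c2nc3ccccc3o2)ccc1O` gives 330 nM; compound 2 `CCOC(=O)c1ccc2nc(/C=C/C=C/c3ccc(O)c(OC)c3)oc2c1` gives 130 nM; compound 3 `Oc1ccc(/C=C/C=C/c2nc3ccccc3o2)cc1O` gives 30 nM.

Compound 1 thus has the highest number of the three: a 2.5-fold lower number from compound 1 to compound 2 (0.40 log units; beyond the scatter) and an 11-fold lower number from compound 1 to compound 3 (1.04 log units; beyond the scatter). Compound 4 `COc1cc(/C=C/C=C/c2nc3cc(CO)ccc3o2)ccc1O` differs from compound 1 by hydroxymethyl in place of hydrogen on an aromatic carbon. Among the measured compounds shown here, of the two measured steps, only the one to compound 2 bears on this, since it also places a group on an aromatic carbon of the core, and it gave a 2.5-fold lower number from compound 1 to compound 2 (0.40 log units; beyond the scatter); the step to compound 3 concerns the other ring. A modest lowering of the number is therefore expected, a 1.7-fold lower number from compound 1 to compound 4 (0.22 log units; within the scatter), while the change is not the same group. Compound 4 is estimated at 200 nM, within 70 nM to 600 nM.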

Compound 4, half-maximal inhibitory concentration: 260 nM
Estimate against measurement, compound 4: 1.3-fold (0.11 log units) below; the measured number falls inside the stated range.
By their numbers in this assay, from the lowest: compound 3; then compounds 2, 4 and 1 (each within the scatter of the next, the first and the last beyond it).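

Hydroxymethyl on this six-membered aromatic ring of carbon only leaves the number in this assay essentially unchanged, with a 1.3-fold lower number from compound 1 to compound 4 (0.10 log units; within the scatter). Among the compounds shown here, the only earlier change on this ring, ethoxycarbonyl, gave a 2.5-fold lower number from compound 1 to compound 2 (0.40 log units; beyond the scatter), so compound 4 shows that a group on this ring need not move the number beyond the scatter. Nothing available explains this result. The compounds shown leave open whether an amine, a carboxylic acid or a longer chain on this same carbon would move the number. They also leave open whether hydroxymethyl would behave alike on the core of compound 3.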